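This account rests on a few compounds, and the source may have more. Where it says the series, first, only, none or still open, it means among the compounds named here.

Working notes on the series. In a functional assay on MCF7 cells (Homo sapiens) for cytotoxicity, read by MTT assay, with a stated time of 3 days (a lower number here means a stronger inhibitor, a higher number a weaker inhibitor), compound 1 `Oc1ccc(-c2cccc(O)c2)cc1` gives only a limit, > 100 ug/mL. Compound 2 `Nc1ccc(-c2cccc(O)c2)cc1`, in this assay, likewise gives only a limit, > 100 ug/mL. The step from compound 1 to compound 2 is therefore a step that the two limits leave unreadable from compound 1 to compound 2; (amino in place of hydroxy on an aromatic carbon). Among the compounds with values here, compound 3 `COc1ccc(-c2ccc(O)cc2)cc1OC` gives the one number of the set, 34 ug/mL in this assay. How the core of compound 3 differs from that of compound 1 is not broken down here. Compound 4 `COc1ccc(-c2ccc(N)cc2)cc1OC` is not yet measured and differs from compound 3 by amino in place of hydroxy on an aromatic carbon, the same kind of change as that from compound 1 to compound 2, though there the place was para to a group of 7 heavy atoms rather than para to a large group. Since the limit of > 100 ug/mL in this assay, at which 2 of the 3 values shown sit, leaves the earlier step unreadable, the expectation for compound 4 rests only on compound 3 at 34 ug/mL: a step of a 1.2-fold higher number from compound 3 to compound 4 (0.07 log units; within the scatter) is estimated. Compound 4 is expected near 40 ug/mL, between 15 ug/mL and 100 ug/mL.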

Compound 4, half-maximal inhibitory concentration: 5.5 ug/mL
Compound 4: the middle estimate sits 7.3-fold (0.86 log units) above what was measured, and the stated range ends above it.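

On the core of compound 3, amino in place of hydroxy gives, in this assay, a 6.2-fold lower number from compound 3 to compound 4 (0.79 log units; beyond the scatter). The same change on the core of compound 1 cannot be read, because compound 1 and compound 2 each give only a limit: the limit of > 100 ug/mL in this assay, at which 2 of the 4 values shown sit. The step therefore stands on one core alone; it shows that the change can matter on that core, but not that its direction or size carries over to another core in this series.

The compounds shown leave open how a dimethylamino group or a carboxylic acid in the same place would read in this assay. Also open, on these data alone, is whether ethoxy in place of methoxy on the core of compound 4 would keep its value.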